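Working notes on compounds 1 to 4 at the carbonyl aryl

The source may hold more compounds than are shown below. What is called first, only, known or untested is meant among the compounds shown, and "the series" means these compounds.

Measured so far:
Compound 1 `CC(C)Nc1sc(C(=O)c2cccnc2)c(N)c1C#N`: in an assay for inhibition of Maternal embryonic leucine zipper kinase (Homo sapiens), read by ADP-Glo, with a stated time of 0.5 h (a higher number here means a weaker inhibitor, a lower number a stronger inhibitor), compound 1 gives only a limit, > 5000 nM.
Compound 2 `CC(C)Nc1sc(C(=O)c2ccco2)c(N)c1C#N`: in this assay compound 2 gives 1350 nM.
Compound 3 `CC(C)Nc1sc(C(=O)c2ccc(I)s2)c(N)c1C#N`: in this assay compound 3 gives 112 nM.

Compound 3 has the lowest number among the measured values; compound 2 is its nearest neighbour, and the value of compound 1 is a limit (the limit of > 5000 nM in this assay, at which 1 of the 3 values shown sits). The group on the carbonyl carbon governs the measured range so far: an at least 3.7-fold lower number from compound 1 to compound 2 (0.56 log units; beyond the scatter), an at least 44-fold lower number from compound 1 to compound 3 (1.64 log units; beyond the scatter) and a 12-fold lower number from compound 2 to compound 3 (1.08 log units; beyond the scatter), all beyond the scatter.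

Compound 4 `CC(C)Nc1sc(C(=O)c2ccc(-c3cccc(O)c3)s2)c(N)c1C#N` differs from compound 3 at the five-membered ring rather than at the carbonyl carbon: 3-hydroxyphenyl in place of iodo on an aromatic carbon. Among the compounds with values here, none of the measured steps exchanges a substituent on that ring, so they bear only indirectly, by showing that this side of the molecule tolerates large shifts in number without loss of the series baseline. A change in this assay of moderate size is expected, more likely toward a lower number than a higher one. The estimate for compound 4 is 60 nM, within 15 nM to 300 nM, meaning an expected step of a 1.9-fold lower number from compound 3 to compound 4 (0.27 log units; within the scatter).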

Compound 4, half-maximal inhibitory concentration: 350 nM
Beside the measured number, compound 4's estimate is 5.8-fold (0.77 log units) below it, outside the stated range (above it).
By their numbers in this assay, from the lowest: compound 3; then compound 4; then compound 2. At a limit, above all of these: compound 1.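

In this assay, within the data shown here, the first exchange on the five-membered ring itself gives a 3.1-fold higher number from compound 3 to compound 4 (0.49 log units; beyond the scatter) with 3-hydroxyphenyl in place of iodo on the aromatic carbon next to the ring sulfur. This carbon therefore carries a whole six-membered aromatic ring with the number staying clear of a limit, yet of these two groups iodo gives the lower number, a direction the other steps could not indicate. Nothing measured here accounts for this step, and it cannot be divided among the loss of iodo, the added ring and the hydroxyl.

Open, going by these compounds, is how an unsubstituted phenyl, a 3-aminophenyl or a 3-carboxyphenyl would compare with 3-hydroxyphenyl on this carbon. Equally open, on these data alone, is whether bromo or chloro in place of iodo would keep a number like that of compound 3.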